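A Ketone on the Chain, Judged from One Step

The source may report more compounds than this note shows. Statements on the series, on what has been measured and on what is new or still open speak of the compounds shown alone.

In a functional assay (trachea) with Cavia porcellus as the target (a higher number here means that more compound is needed for the effect, a lower number that less compound is needed), compound 1 `CCCn1c(=O)n(C)c(=O)c2c1ncn2CC#N` gives 35300 nM, and compound 2 `CCCn1c(=O)n(C)c(=O)c2c1ncn2CCOC` gives 36100 nM. Compound 2 therefore stands level with compound 1, the two values lying within the scatter of each other. Compound 3 `CCCn1c(=O)n(C)c(=O)c2c1ncn2CCC(C)=O` has not yet been measured. It departs from compound 2 by acetyl in place of methoxy on a saturated chain carbon, two bonds along the chain from an aromatic nitrogen, with acetyl in place of methoxy on a saturated chain carbon, two bonds along the chain from an aromatic nitrogen.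

For the measured compounds named here, only one measured step bears on this change. This is a 1.0-fold higher number from compound 1 to compound 2 (0.01 log units; within the scatter), where methoxymethyl takes the place of cyano on a saturated chain carbon bound to an aromatic nitrogen. Going by the values given here, it stays within the scatter, but it is a single step, and no measured pair exchanges methoxy for acetyl. The evidence is therefore indirect, and the range must stay wide. On the strength of that one step, the expected change is a 1.0-fold lower number from compound 2 to compound 3 (0.00 log units; within the scatter), which means no expected shift beyond the scatter in either direction. The estimate for compound 3 is 36000 nM, with an expected range from 16000 nM to 80000 nM.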

Compound 3, half-maximal effective concentration: 12200 nM
Estimate against measurement, compound 3: 3.0-fold (0.47 log units) above; measured number below the stated range.
By their numbers in this assay, from the lowest: compound 3; then compounds 1 and 2 (each within the scatter of the next).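

In this assay the end of this chain now proves able to move the number, which the earlier pair of compounds gave no sign of: acetyl in place of methoxy gives a 3.0-fold lower number from compound 2 to compound 3 (0.47 log units; beyond the scatter) and, on the carbon bound to the aromatic nitrogen, 2-oxopropyl in place of cyano gives a 2.9-fold lower number from compound 1 to compound 3 (0.46 log units; beyond the scatter) on the same core. Since compound 1 and compound 2 stand within the scatter of each other, these two steps describe one result, with the ketone-bearing chain set apart from both the nitrile and the methoxy chain. Methoxy and acetyl carry the same count of hydrogen-bond acceptors and no net charge, so those counts do not separate compound 2 from compound 3; what the change adds is one heavy atom and a double bond outside the aromatic rings.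

Going by these compounds, whether the lower number belongs to the carbonyl itself or to the chain as a whole stays open, as does what an amine, a carboxylic acid, a hydroxyl or a longer chain ending in a ketone would do at this place. Nothing among the data shown accounts for the shift, which remains an observation without an explanation.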